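Cytotoxicity in Vero cells: from methoxy to chloro

The source may report more compounds than this note shows. Statements on the series, on what has been measured and on what is new or still open speak of the compounds shown alone.

Measured compounds:
compound 1, `COc1ccc(C2SCC(=O)N2CCN2CCCCC2)cc1`: 11%
compound 2, `Cc1ccc(C2SCC(=O)N2CCN2CCCCC2)cc1`: 13%

Of the compounds shown here, two sharing one core have been measured in an ADME assay on Vero cells (Chlorocebus sabaeus) for cytotoxicity, read by neutral red uptake, tested at 1575 ug/mL; on this read-out lower numbers stand for a stronger effect and higher numbers for a weaker effect at the one concentration tested. Compound 1 gives 11% in this assay, and compound 2 gives 13%. Compound 1 stands at one end of these two numbers, but only just: its nearest neighbour is compound 2, and the change between them, methyl in place of methoxy on an aromatic carbon, gave a number 2 percentage points higher from compound 1 to compound 2 (within the scatter), a step that lies within the scatter of the measurement.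

The unmeasured compound 3, `O=C1CSC(c2ccc(Cl)cc2)N1CCN1CCCCC1`, differs from compound 1 by chloro in place of methoxy on an aromatic carbon. Among the compounds with values here, the only measured step that bears on this change is the one from compound 1 to compound 2, which altered the same group at the same place and produced no step beyond the scatter. Nothing measured here points toward a shift in either direction for a chloro group, so no change beyond the scatter is expected, the step being estimated as a number 2 percentage points higher from compound 1 to compound 3 (within the scatter). Compound 3 is therefore expected to give about 13% in this assay, within a range from 4% to 24%.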

Compound 3, a percentage reported as activity, at one concentration (the size of the read-out at that concentration, not a potency): 13%
The estimate for compound 3 equals the measured number at the digits printed, within the range that was stated.
By their numbers in this assay, from the lowest: compounds 1, 2 and 3 (each within the scatter of the next).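

In this assay, the place on the six-membered aromatic ring para to a large group has now held three different groups, and the new exchange gave a number 2 percentage points higher from compound 1 to compound 3 (within the scatter) with chloro in place of methoxy and no change at the digits printed from compound 2 to compound 3 (within the scatter) with chloro in place of methyl. Within the data shown here, the earlier pair showed only one exchange at this place, whereas these steps show that a single chlorine atom, with no hydrogen-bond acceptor, also stays within the scatter of both methoxy, which has one acceptor, and methyl, so across these three compounds the read-out does not separate the groups. No measurement shown here accounts for this agreement among the three compounds.

As far as these compounds go, what remains open is whether a group of a different kind at this place, such as an amine, a carboxylic acid or a nitrile, would also stay within the scatter of these three compounds. The compounds shown also leave open how the read-out responds to changes elsewhere on the shared core, and how these compounds compare at any other concentration.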